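This account rests on a few compounds, and the source may have more. Where it says the series, first, only, none or still open, it means among the compounds named here.

Measured so far in a functional assay on NCI-H460 cells (Homo sapiens) for antiproliferative activity, read by CCK-8 assay, with a stated time of 72 h, tested at 2 uM; a higher number here means a stronger effect of the compound at the concentration tested, a lower number a weaker effect:
compound 1 `CC(C)n1cnc2c(Nc3cccc(Cl)c3)nc(NCOCc3ccc(C(=O)Nc4ccccc4N)cc3)nc21` gives 28.9%
compound 2 `CC(C)n1cnc2c(Nc3cccc(Cl)c3)nc(NCOCc3ccc(/C=C/C(=O)Nc4ccccc4N)cc3)nc21` gives 53%
compound 3 `CCCCn1cnc2c(Nc3ccccc3)nc(NCOCc3ccc(/C=C/C(=O)Nc4ccccc4N)cc3)nc21` gives 23.1%

Compound 1 arises from compound 2 by (2-aminophenyl)carbamoyl in place of 2-((2-aminophenyl)carbamoyl)ethenyl on an aromatic carbon, and this assay records a number 24.1 percentage points lower from compound 2 to compound 1 (beyond the scatter). Compound 4 `CCCCn1cnc2c(Nc3ccccc3)nc(NCOCc3ccc(C(=O)Nc4ccccc4N)cc3)nc21` is made from compound 3 by (2-aminophenyl)carbamoyl in place of 2-((2-aminophenyl)carbamoyl)ethenyl on an aromatic carbon, the same change at the same place, on a different core. How the core of compound 3 differs from that of compound 2 is not broken down here. Compound 3 stands lower than compound 2 in this assay, while its value and that of compound 1 lie within the usual scatter of each other.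

Because the earlier step of a number 24.1 percentage points lower from compound 2 to compound 1 (beyond the scatter) was modest but clear, compound 4 is expected to fall further, to an estimated 6%, a step of a number 17.1 percentage points lower from compound 3 to compound 4 (beyond the scatter), bounded by the floor of the read-out.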

Compound 4, a percentage reported as inhibition, at one concentration (the size of the read-out at that concentration, not a potency): 27.7%
Beside the measured number, compound 4's estimate is 21.7 percentage points below it, and the stated range ends below it.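

In this assay, putting (2-aminophenyl)carbamoyl in place of 2-((2-aminophenyl)carbamoyl)ethenyl gives a number 4.6 percentage points higher from compound 3 to compound 4 (within the scatter), so this change has no clear effect on this core. The effect of the change therefore did not carry over unchanged from one core to the other: the same change on two cores in this assay, a number 24.1 percentage points lower (beyond the scatter) from compound 2 to compound 1 and a number 4.6 percentage points higher (within the scatter) from compound 3 to compound 4, 28.7 percentage points apart, beyond the scatter of two such steps. This shows that, in these two pairs, the outcome of the change depends on the core, but it does not show which part of the core matters, and two pairs set no rule for the series.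

The compounds shown leave open how the change behaves on a core that differs from that of compound 2 in only one place. They also leave open what a hydroxamic acid would do in place of the 2-aminophenyl amide.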